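Amide cap variation on a shared sulfonamide scaffold

A few compounds are considered here, and "the series" means these few. Any claim that something is new, unique, unknown or untested is made for them only; others in the source may bear on it.

Measured compounds in an assay on isolated protein for binding affinity to secreted frizzled-related protein 1 (Homo sapiens), read by fluorescence; on this read-out higher numbers stand for weaker inhibition and lower numbers for stronger inhibition:
compound 1 `O=C(Cn1ccnc1)N1CCC(NS(=O)(=O)c2cc(S(=O)(=O)c3ccccc3)ccc2C(F)(F)F)CC1` — 30 nM
compound 2 `CC(C)(C)CC(=O)N1CCC[C@H]1C(=O)N1CCC(NS(=O)(=O)c2cc(S(=O)(=O)c3ccccc3)ccc2C(F)(F)F)CC1` — 20 nM
compound 3 `CCNC(=O)N1CCC[C@H]1C(=O)N1CCC(NS(=O)(=O)c2cc(S(=O)(=O)c3ccccc3)ccc2C(F)(F)F)CC1` — 30 nM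

Compound 1 sits level with compound 3 at the digits shown, the two together giving the highest numbers of the three; its furthest neighbour is compound 2, with a 1.5-fold lower number from compound 1 to compound 2 (0.18 log units; within the scatter), and even that lies within the scatter. All three numbers therefore describe one plateau.

Compound 4 `CN(C)C(=O)N1CCC[C@H]1C(=O)N1CCC(NS(=O)(=O)c2cc(S(=O)(=O)c3ccccc3)ccc2C(F)(F)F)CC1` is not yet measured. Its change from compound 1 is 1-(dimethylcarbamoyl)pyrrolidin-2-yl in place of (1H-imidazol-1-yl)methyl on a carbonyl carbon. Within the data shown here, two measured steps bear on it directly, since each also exchanges the (1H-imidazol-1-yl)methyl group for a 1-acylated pyrrolidin-2-yl group: a 1.5-fold lower number from compound 1 to compound 2 (0.18 log units; within the scatter) and no change at the digits printed from compound 1 to compound 3 (within the scatter). The remaining step, a 1.5-fold higher number from compound 2 to compound 3 (0.18 log units; within the scatter), shows that the group on the pyrrolidine carbonyl also moves the number only within the scatter. Among the measured compounds shown here, no step in this set leaves the plateau, so for compound 4 a step of a 1.2-fold lower number from compound 1 to compound 4 (0.08 log units; within the scatter) is expected, with no direction beyond the scatter. Compound 4 is estimated at 25 nM in this assay, within a range of 12 nM to 55 nM.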

Compound 4, half-maximal inhibitory concentration: 30 nM
Compound 4: middle estimate off by 1.2-fold (0.08 log units), on the low side; measured number inside the range.
By their numbers in this assay, from the lowest: compounds 2, 1, 3 and 4 (each within the scatter of the next).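

In this assay the larger 1-(dimethylcarbamoyl)pyrrolidin-2-yl in place of (1H-imidazol-1-yl)methyl on a carbonyl carbon gives no change at the digits printed from compound 1 to compound 4 (within the scatter) and so stays on the plateau, while dimethylamino in place of ethylamino gives no change at the digits printed from compound 3 to compound 4 (within the scatter) and shows that the hydrogen on that nitrogen in compound 3 can go without a readable change. Dimethylamino in place of neopentyl gives a 1.5-fold higher number from compound 2 to compound 4 (0.18 log units; within the scatter) and stays within the scatter as well, so all four compounds remain one plateau and no group here sets itself apart. No measurement on hand offers a reason for this flatness.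

Going by these compounds, whether any group on this carbonyl carbon can leave the plateau stays open. A carboxylic acid, a primary amine or a longer alkyl chain in place of dimethylamino would test this, and the role of the defined stereocentre is also unresolved.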